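Estimating a Nitrile Replacement in a Cytotoxicity Series

The source may report more compounds than this note shows. Statements on the series, on what has been measured and on what is new or still open speak of the compounds shown alone.

Measured compounds:
compound 1, `CN(C)CC[C@H](CSc1ccccc1)Nc1ccc(S(=O)(=O)NC(=O)c2ccc(N3CCN(Cc4ccccc4-c4ccc(Cl)cc4)CC3)cc2)cc1C(F)(F)F`: 2460 nM
compound 2, `CN(C)CC[C@H](CSc1ccccc1)Nc1ccc(S(=O)(=O)NC(=O)c2ccc(N3CCN(Cc4ccccc4-c4ccc(Cl)cc4)CC3)cc2)cc1S(C)(=O)=O`: 34900 nM
compound 3, `CN(C)CC[C@H](CSc1ccccc1)Nc1ccc(S(=O)(=O)NC(=O)c2ccc(N3CCN(Cc4ccccc4-c4ccc(Cl)cc4)CC3)cc2)cc1C(=O)C(F)(F)F`: 2010 nM

In a functional assay on NCI-H146 cells (Homo sapiens) for cytotoxicity, with a stated time of 48 h, in the presence of a further agent that is not named here (on this read-out lower numbers stand for an effect already at smaller amounts and higher numbers for an effect only at larger amounts of compound), compound 3 gives the lowest number of the three, but compound 1 sits so close to it that the two are within the scatter and cannot be ordered; compound 2 lies far off, with a 17-fold lower number from compound 2 to compound 3 (1.24 log units; beyond the scatter) marking a step well beyond the scatter. Compound 4, `CN(C)CC[C@H](CSc1ccccc1)Nc1ccc(S(=O)(=O)NC(=O)c2ccc(N3CCN(Cc4ccccc4-c4ccc(Cl)cc4)CC3)cc2)cc1C#N`, is the unmeasured member. It differs from compound 3 by cyano in place of (trifluoromethyl)carbonyl on an aromatic carbon.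

Among the compounds with values here, two measured steps bear on this change. The step of a 1.2-fold lower number from compound 1 to compound 3 (0.09 log units; within the scatter) shows that exchanging trifluoromethyl for (trifluoromethyl)carbonyl at this position leaves the number essentially unchanged. The step of a 14-fold higher number from compound 1 to compound 2 (1.15 log units; beyond the scatter) shows that putting methylsulfonyl there instead raises it strongly. Within the data shown here, no measured pair shows a cyano group, so the direction for compound 4 rests on these two neighbours only: a group at this position can be swapped with little effect, or can cost a great deal. Cyano is expected to fall between these cases, so compound 4 is estimated to give a somewhat higher number, a 1.7-fold higher number from compound 3 to compound 4 (0.24 log units; within the scatter), with a wide range.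

Compound 4 is therefore estimated at 3500 nM, in a range from 1200 nM to 12000 nM in this assay.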

Compound 4, half-maximal effective concentration: 1930 nM
Compound 4: the middle estimate sits 1.8-fold (0.26 log units) above what was measured, and the stated range covers the measured number.
By their numbers in this assay, from the lowest: compounds 4, 3 and 1 (each within the scatter of the next); then compound 2.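

In this assay the cyano group takes the place of (trifluoromethyl)carbonyl with a 1.0-fold lower number from compound 3 to compound 4 (0.02 log units; within the scatter) and stands in for trifluoromethyl with a 1.3-fold lower number from compound 1 to compound 4 (0.11 log units; within the scatter) as well, so three different groups on this aromatic carbon now give numbers that cannot be ordered. The change from (trifluoromethyl)carbonyl to cyano takes the group from 6 heavy atoms to 2, with a double bond replaced by a triple bond, and the number stays within the scatter, so across compounds 1, 3 and 4 this position tolerates these differences. Methylsulfonyl is now the lone outlier among the four groups, as an 18-fold lower number from compound 2 to compound 4 (1.26 log units; beyond the scatter) shows, a step about as large as those already seen for the other two groups, so the large penalty belongs to compound 2 alone.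

The compounds shown leave open whether an amine, a carboxylic acid or a plain methyl at this position would stay with the group of three or fall with methylsulfonyl, and whether a bare hydrogen there would give a similar number. Nothing measured here accounts for why methylsulfonyl parts from the other three groups.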